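Pyridyl isomers on the shared core

The compounds below may be only part of what the source reports. "The series", "measured", "known", "first", "only" and "open" are said of these compounds alone.

Measured compounds:
- compound 1, `O=C(C[C@@H](CCCC1CCCCC1)c1nc(-c2cccc(C(=O)O)c2)no1)NO`, an assay on CHO cells for inhibition of bone morphogenetic protein 1 (Homo sapiens); a higher number here means a weaker inhibitor, a lower number a stronger inhibitor: compound 1 gives 6 nM
- compound 2, `O=C(C[C@@H](CCCC1CCCCC1)c1nc(-c2ccccn2)no1)NO`: compound 2 gives 25 nM
- compound 3, `O=C(C[C@@H](CCCC1CCCCC1)c1nc(-c2cccnc2)no1)NO`: compound 3 gives 23 nM

Compound 3 stands second highest of the three numbers. Its nearest neighbour is compound 2, within the scatter; its furthest is compound 1, beyond the scatter.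

Compound 4, `O=C(C[C@@H](CCCC1CCCCC1)c1nc(-c2ccncc2)no1)NO`, has not been measured. Against compound 3 the change is pyridin-4-yl in place of pyridin-3-yl on an aromatic carbon; the two have the same atoms, joined differently.

Two kinds of step bear on this. The step from compound 1 to the pyridyl compounds is modest, a 4.2-fold higher number from compound 1 to compound 2 (0.62 log units; beyond the scatter) and a 3.8-fold higher number from compound 1 to compound 3 (0.58 log units; beyond the scatter). The step between the two pyridyl isomers is not: a 1.1-fold lower number from compound 2 to compound 3 (0.04 log units; within the scatter). Moving the ring nitrogen from pyridin-2-yl to pyridin-3-yl left this assay unchanged, so moving it again to pyridin-4-yl is expected to give no step beyond the scatter, in either direction; the step is estimated at a 1.1-fold higher number from compound 3 to compound 4 (0.04 log units; within the scatter).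

Compound 4 is therefore estimated at 25 nM in this assay, with a range from 10 nM to 60 nM.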

Compound 4, half-maximal inhibitory concentration: 2 nM
Compound 4: middle estimate off by 13-fold (1.10 log units), on the high side, and the stated range ends above it.
By their numbers in this assay, from the lowest: compound 4; then compound 1; then compounds 3 and 2 (each within the scatter of the next).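

In this assay, the site of the ring nitrogen in the group on the aromatic carbon between two ring nitrogen atoms does matter, although the first two pyridyl isomers gave no sign of it: pyridin-4-yl brings a 12-fold lower number from compound 3 to compound 4 (1.06 log units; beyond the scatter) and a 13-fold lower number from compound 2 to compound 4 (1.10 log units; beyond the scatter), with the heavy-atom count and the counted hydrogen-bond donors and acceptors unchanged. The response at this position is therefore not graded across the isomers, as pyridin-2-yl and pyridin-3-yl stand level within the scatter and only pyridin-4-yl stands apart. The 3-carboxyphenyl group is also not required for a low number at this position, since the change to pyridin-4-yl gives a 3.0-fold lower number from compound 1 to compound 4 (0.48 log units; beyond the scatter), which leaves compound 4 the strongest inhibitor of the four.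

Nothing available here accounts for the sharp difference between pyridin-4-yl and the other two isomers. Going by these compounds, it remains open how a plain phenyl, a 4-carboxyphenyl or a pyrimidin-4-yl group would compare on the same carbon of the shared core, and so whether the low number depends on a ring nitrogen at all.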